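Swapping Fluoro for Methoxy on a Phenoxy Ring

This account rests on a few compounds, and the source may have more. Where it says the series, first, only, none or still open, it means among the compounds named here.

Three close relatives have been tested in a functional assay on SMMC-7721 cells (Homo sapiens) for inhibition, read by MTT assay, with a stated time of 72 h, tested at 25 uM; on this read-out higher numbers stand for more inhibition at the one concentration tested (going by the name of the read-out) and lower numbers for less inhibition. Compound 1 , `CCc1nn(C)c(CO/N=C/c2c(C)nn(C)c2Oc2ccccc2F)c1Cl`, carries a fluoro group on a phenoxy ring. In this assay compound 1 reaches only < 80%, which is a limit of the assay and not a number. Compound 2 , `Cc1nn(C)c(Oc2ccc(Br)cc2)c1/C=N\OCc1c(Cl)c(-c2ccc(Cl)cc2)nn1C`, gives 80% in this assay. Compound 3 , `CCc1nn(C)c(CO/N=C\c2c(C)nn(C)c2Oc2ccc(OC)cc2)c1Cl`, again comes back with < 80%, a limit rather than a number. Because (the limit of < 80% in this assay, at which 2 of the 3 values shown sit), most of what is known so far is that inhibition fell short of the threshold, so no measured step between any two of these compounds can be stated.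

Compound 4 , `CCc1nn(C)c(CO/N=C/c2c(C)nn(C)c2Oc2ccccc2OC)c1Cl`, is not yet measured. It differs from compound 1 in one place: methoxy in place of fluoro on an aromatic carbon. Within the data shown here, no step between measured compounds is available to size this change, and compound 3, which also carries a methoxy group, does not rise above the limit either. Compound 4 is therefore expected to stay near the limit, with a change a step that the limit leaves unreadable from compound 1 to compound 4 that is not expected to go beyond the scatter. The estimate for compound 4 in this assay is 55%, expected to lie between 20% and 85%.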

Compound 4, a percentage reported as inhibition, at one concentration (the size of the read-out at that concentration, not a potency): < 80%
Compound 4 gave a limit, no number; the forecaster's own chance of this, stated with the estimate: 70%; the middle value does not contradict the limit.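

Compound 1 and compound 4 both return limits rather than numbers in this assay, so no step can be read for methoxy in place of fluoro: the limit of < 80% in this assay, at which 3 of the 4 values shown sit. The compounds shown leave open how much inhibition compound 1 and compound 4 actually reach, and whether this swap changes it at all.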